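A Small Step Expected from Swapping One Aryl Group

The source may hold more compounds than are shown below. What is called first, only, known or untested is meant among the compounds shown, and "the series" means these compounds.

Of the compounds shown here, three sharing one core have been tested in a functional assay on KB cells (Homo sapiens) for antiproliferative activity, read by sulforhodamine B assay, with a stated time of 3 days; on this read-out higher numbers stand for an effect only at larger amounts of compound and lower numbers for an effect already at smaller amounts. Compound 1 (`CCC1=C(O)c2c(oc(-c3ccc(C)cc3C)cc2=O)C(CC)(CC)C1=O`) gives 41.2 uM, compound 2 (`CCC1=C(O)c2c(oc(-c3ccc(OC)c(C)c3)cc2=O)C(CC)(CC)C1=O`) gives 28.5 uM and compound 3 (`CCC1=C(O)c2c(oc(-c3ccc(OC)c(F)c3)cc2=O)C(CC)(CC)C1=O`) gives 26.7 uM. Compound 3 therefore stands level with the other two, since every gap among the three lies within the scatter.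

Compound 4 (`CCC1=C(O)c2c(oc(-c3cc(C)cc(C)c3)cc2=O)C(CC)(CC)C1=O`) has not yet been measured. It carries 3,5-dimethylphenyl in place of 3-fluoro-4-methoxyphenyl on an aromatic carbon next to the ring oxygen, and the exchange comes to 3,5-dimethylphenyl in place of 3-fluoro-4-methoxyphenyl on an aromatic carbon.

Among the measured compounds shown here, three measured steps bear on this change. Exchanging the whole aryl group gave a 1.4-fold lower number from compound 1 to compound 2 (0.16 log units; within the scatter) and a 1.5-fold lower number from compound 1 to compound 3 (0.19 log units; within the scatter), while fluoro in place of methyl gave a 1.1-fold lower number from compound 2 to compound 3 (0.03 log units; within the scatter). Among these three compounds, then, changes to this group have not moved the number beyond the scatter. For the measured compounds named here, compound 1 also carries a dimethylphenyl group, at 41.2 uM, so a slightly higher number would not surprise, but no measured compound has the exact new group. The expected change is a 1.2-fold higher number from compound 3 to compound 4 (0.08 log units; within the scatter), which is no step beyond the scatter. Compound 4 is estimated at 32 uM, with an expected range of 18 uM to 55 uM.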

Compound 4, concentration for half-maximal effect: 45.5 uM
The estimate for compound 4 lay 1.4-fold (0.15 log units) below the measured number; low and high end bracket the measured number.
By their numbers in this assay, from the lowest: compounds 3, 2, 1 and 4 (each within the scatter of the next).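

In this assay, replacing 3-fluoro-4-methoxyphenyl, which has one hydrogen-bond acceptor, with 3,5-dimethylphenyl, which has none, gives a 1.7-fold higher number from compound 3 to compound 4 (0.23 log units; within the scatter), and replacing 4-methoxy-3-methylphenyl with the same group gives a 1.6-fold higher number from compound 2 to compound 4 (0.20 log units; within the scatter), so this position has now taken a group with neither fluoro nor methoxy without a step beyond the scatter. Placing the two methyl groups as in 3,5-dimethylphenyl instead of 2,4-dimethylphenyl gives a 1.1-fold higher number from compound 1 to compound 4 (0.04 log units; within the scatter), so the compounds shown do not separate these two arrangements of the same two substituents. No outside measurement is available to explain these small differences.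

As far as these compounds go, all four aryl groups are phenyl rings carrying only methyl, methoxy or fluoro, so it remains open whether an amine, a carboxylic acid or a longer chain such as butyl on that ring would move the number beyond the scatter. From the compounds shown here alone, the ethyl groups on the shared core are the same in all four compounds, so the effect of changing them also remains open.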